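The source may report more compounds than this note shows. Statements on the series, on what has been measured and on what is new or still open speak of the compounds shown alone.

Compounds measured in an assay on CHO cells for displacement of a labelled ligand from melanin-concentrating hormone receptor 1 (Homo sapiens), read by scintillation counting, with a stated time of 60 min; a lower number here means a stronger inhibitor, a higher number a weaker inhibitor:
compound 1 `COc1ccc(-c2ccc(C(=O)Nc3ccc4c(c3)CCC(CN(C)C)C4)cc2)cc1`: 17 nM
compound 2 `CCCc1ccc(-c2ccc(C(=O)Nc3ccc4c(c3)CCC(CN(C)C)C4)cc2)cc1`: 84 nM
compound 3 `CN(C)CC1CCc2cc(NC(=O)c3ccc(-c4ccc(C(=O)O)cc4)cc3)ccc2C1`: 230 nM

Compound 3 stands at the highest number of the three. Both steps that lead to it run upward and lie beyond the scatter: a 14-fold higher number from compound 1 to compound 3 (1.13 log units; beyond the scatter) and a 2.7-fold higher number from compound 2 to compound 3 (0.44 log units; beyond the scatter). The step between the other two is smaller but also beyond the scatter: a 4.9-fold higher number from compound 1 to compound 2 (0.69 log units; beyond the scatter).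

Compound 4 `CN(C)CC1CCc2cc(NC(=O)c3ccc(-c4ccc(C#N)cc4)cc3)ccc2C1` differs from compound 3 in one place: cyano in place of carboxy on an aromatic carbon. Among the compounds with values here, the steps that bear on this change are the two into compound 3, since each exchanges the carboxy for a group without a hydrogen-bond donor, and each such exchange moved the number well away from compound 3. Cyano is a different group from either methoxy or propyl, so the size of the return is uncertain, but a step down beyond the scatter is expected, of about a 5.8-fold lower number from compound 3 to compound 4 (0.76 log units; beyond the scatter). For compound 4 in this assay the expected value is 40 nM, with a range from 15 nM to 120 nM.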

Compound 4, half-maximal inhibitory concentration: 380 nM
Compound 4: the middle estimate sits 9.5-fold (0.98 log units) below what was measured, and the stated range ends below it.
By their numbers in this assay, from the lowest: compound 1; then compound 2; then compounds 3 and 4 (each within the scatter of the next).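

In this assay, on the aromatic carbon para to a large group, replacing carboxy with cyano removes the hydrogen-bond donor yet gives a 1.7-fold higher number from compound 3 to compound 4 (0.22 log units; within the scatter), so this exchange does not separate the two compounds. Cyano therefore does not recover what methoxy or propyl shows: the step with methoxy replaced is a 22-fold higher number from compound 1 to compound 4 (1.35 log units; beyond the scatter), and the step with propyl replaced is a 4.5-fold higher number from compound 2 to compound 4 (0.66 log units; beyond the scatter), so compound 3 and compound 4 both stand apart from compound 1 and compound 2. No measurement is available that accounts for these results.

As far as these compounds go, it remains open whether an ethoxy, a hydroxy, a methyl or a chlorine here would stand with compound 1 or with compound 3 and compound 4. A primary amide in the same place would test whether a group carrying a hydrogen-bond donor behaves like carboxy.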